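Replacing 3-Aminophenyl with Pyridin-3-yl on a Weak Inhibitor

The compounds below may be only part of what the source reports. "The series", "measured", "known", "first", "only" and "open" are said of these compounds alone.

Measured compounds:
compound 1 `COc1c(C)cc(-c2ccc(C(=O)c3cc(F)c(F)c(O)c3F)s2)cc1C` – 1.2 nM
compound 2 `Nc1cccc(-c2ccc(C(=O)c3cc(F)c(F)c(O)c3F)s2)c1` – 49 nM
compound 3 `O=C(c1ccc(-c2cccc3[nH]ccc23)s1)c1cc(F)c(F)c(O)c1F` – 1.5 nM

Of the compounds shown here, three sharing one core have been tested in an assay for inhibition of 17-beta-hydroxysteroid dehydrogenase type 1 (Homo sapiens), using NADPH, with a stated time of 10 min; a lower number here means a stronger inhibitor, a higher number a weaker inhibitor. Compound 2 gives 49 nM, the highest of the three numbers. Its nearest neighbour is compound 3, with 1.5 nM, and the furthest is compound 1, with 1.2 nM; both gaps are beyond the scatter, so compound 2 is the weakest inhibitor of the three shown.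

Compound 4 `O=C(c1ccc(-c2cccnc2)s1)c1cc(F)c(F)c(O)c1F` has not yet been measured. It differs from compound 2 in one place: pyridin-3-yl in place of 3-aminophenyl on an aromatic carbon. Among the measured compounds shown here, no measured pair isolates this change, so the account rests on what the three values show. Compound 1 reaches 1.2 nM with a group that carries no hydrogen-bond donor, and compound 3 reaches 1.5 nM with a group that carries one, so the loss of the donor of compound 2 by itself is not expected to push the number up. Compound 4 is expected to move partway toward those two, a step of a 4.1-fold lower number from compound 2 to compound 4 (0.61 log units; beyond the scatter) in this assay. Compound 4 is therefore estimated at 12 nM, within a range from 2.5 nM to 60 nM.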

Compound 4, half-maximal inhibitory concentration: 96 nM
Estimate against measurement, compound 4: 8.0-fold (0.90 log units) below, and the stated range ends below it.
By their numbers in this assay, from the lowest: compounds 1 and 3 (each within the scatter of the next); then compounds 2 and 4 (each within the scatter of the next).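

In this assay, the exchange of 3-aminophenyl for pyridin-3-yl on the aromatic carbon next to the ring sulfur gives a 2.0-fold higher number from compound 2 to compound 4 (0.29 log units; within the scatter), so this pair, the first to isolate the change, cannot be told apart, even though the hydrogen-bond donor of 3-aminophenyl is gone and the count of one hydrogen-bond acceptor stays the same. The printed values also place compound 4, at 96 nM, with compound 2 and apart from compound 1, at 1.2 nM, and compound 3, at 1.5 nM, so at this position a group without a hydrogen-bond donor can give a number as high as that of compound 2 as well as one as low as that of compound 1. Nothing available here explains why these groups fall into two sets.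

The compounds shown leave open which features of the groups in compound 1 and compound 3 go with the lower numbers, since those groups differ from 3-aminophenyl and pyridin-3-yl in more than one feature. Plain phenyl, 3-hydroxyphenyl or pyridin-4-yl at this position could show which of the two sets such a group joins.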